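Two Halogens on the Ring, One Position Untested

The compounds below may be only part of what the source reports. "The series", "measured", "known", "first", "only" and "open" are said of these compounds alone.

Compound 1 `CC1CCN(C2CCN(S(=O)(=O)c3cccc(C(F)(F)F)c3)CC2)CC1` gives in a functional assay on DLD-1 cells (Homo sapiens) for antiproliferative activity, read by CellTiter-Glo, with a stated time of 72 h (on this read-out higher numbers stand for weaker inhibition and lower numbers for stronger inhibition), only a limit, > 5000 nM. Compound 2 `CC1CCN(C2CCN(S(=O)(=O)c3cccc(Cl)c3)CC2)CC1` likewise gives only a limit in this assay, > 5000 nM. Compound 3 `CC1CCN(C2CCN(S(=O)(=O)c3ccc(Cl)c(C(F)(F)F)c3)CC2)CC1` gives in this assay 17 nM.

The change from compound 1 to compound 2 is chloro in place of trifluoromethyl on an aromatic carbon. Since both of these compounds sit at the limit of > 5000 nM in this assay, at which 2 of the 3 values shown sit, the step that the two limits leave unreadable from compound 1 to compound 2 cannot be sized. The two cores differ by chloro in place of hydrogen on an aromatic carbon, and that step is an at least 290-fold lower number from compound 1 to compound 3 (2.46 log units; beyond the scatter), a large drop in the number. Compound 4 `CC1CCN(C2CCN(S(=O)(=O)c3ccc(Cl)c(Cl)c3)CC2)CC1` has not been measured in this assay. It differs from compound 3 by chloro in place of trifluoromethyl on an aromatic carbon. This is the same kind of change as from compound 1 to compound 2, but here the place is ortho to a chloro group (1 heavy atom) as well as meta to a large group, so the two settings are not alike.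

With the earlier step unreadable, the expectation for compound 4 can rest only on compound 3 and is an estimated step of a 2.4-fold higher number from compound 3 to compound 4 (0.37 log units; beyond the scatter). For compound 4 the estimated value in this assay is 40 nM, with a range from 10 nM to 250 nM.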

Compound 4, half-maximal inhibitory concentration: 2.9 nM
For compound 4 the middle estimate is 14-fold (1.14 log units) above the measured one, outside the stated range (below it).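

Chloro in place of hydrogen on an aromatic carbon now appears on a second core in this assay, where it gives an at least 1700-fold lower number from compound 2 to compound 4 (3.23 log units; beyond the scatter). Both cases point the same way, a large drop in the number, but how far they agree in size cannot be said: the same change on two cores in this assay, an at least 290-fold lower number (2.46 log units; beyond the scatter) from compound 1 to compound 3 and an at least 1700-fold lower number (3.23 log units; beyond the scatter) from compound 2 to compound 4; the limit leaves it open whether they differ The swap of trifluoromethyl for chloro gives a 5.9-fold lower number from compound 3 to compound 4 (0.77 log units; beyond the scatter) on the core that carries a chloro group, while the same swap without that chloro group cannot be read, so this result cannot be said to carry over from one core to the other: the limit of > 5000 nM in this assay, at which 2 of the 4 values shown sit.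

On these data alone, the actual potencies of compound 1 and compound 2 remain open, and with them the true size of every step that starts from either compound. Also open, as far as these compounds go, is what a bromo group, a methoxy group or an amine would give in place of the chloro group that compound 3 and compound 4 share.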